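Iodo for nitro on an alkyne-linked cyanophenyl antagonist

The compounds below may be only part of what the source reports. "The series", "measured", "known", "first", "only" and "open" are said of these compounds alone.

Measured compounds:
compound 1, `Cc1nc(C#Cc2cc(Cl)cc(C#N)c2)cs1`, 1.61 nM
compound 2, `Cc1cccc(C#Cc2cc(C#N)cc([N+](=O)[O-])c2)n1`, 3.68 nM

The two measured compounds were tested in a functional assay on HEK293 cells for antagonist activity at metabotropic glutamate receptor 5 (Rattus norvegicus), read by calcium flux; on this read-out higher numbers stand for weaker inhibition and lower numbers for stronger inhibition. Compound 1 gives 1.61 nM, while compound 2 gives 3.68 nM. Compound 2 therefore stands at the higher of the two numbers, and the gap to compound 1 lies beyond the usual scatter of repeated measurements, so compound 2 is the weaker inhibitor of the pair.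

The next compound, compound 3, is `Cc1cccc(C#Cc2cc(I)cc(C#N)c2)n1`. Its structure differs from compound 2 in one place: iodo in place of nitro on an aromatic carbon.

Among the measured compounds shown here, no measured pair shows this exact change, so the size of the step can only be expected. Compound 1 carries a halogen at a comparable site and gives 1.61 nM, which suggests a halogen is well tolerated. Compound 3 is therefore expected to move modestly toward stronger inhibition, a 1.5-fold lower number from compound 2 to compound 3 (0.17 log units; within the scatter). The estimate for compound 3 in this assay is 2.5 nM, with a range from 0.8 nM to 8 nM.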

Compound 3, half-maximal inhibitory concentration: 0.71 nM
Compound 3: middle estimate off by 3.5-fold (0.55 log units), on the high side; measured number below the stated range.
By their numbers in this assay, from the lowest: compound 3; then compound 1; then compound 2.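

In this assay, iodo in place of nitro on this aromatic carbon, meta to a cyano group, gives a 5.2-fold lower number from compound 2 to compound 3 (0.71 log units; beyond the scatter), a step toward stronger inhibition. The position thus accepts a single iodine atom in place of the three heavy atoms of nitro, and inhibition at this level does not depend on the two hydrogen-bond acceptors that leave with nitro. Nothing measured here explains the size of this step.

The compounds shown leave open whether this gain is particular to iodo or would extend to other groups at this position on the same core, such as an amine or a methoxy group. Chloro appears only in compound 1, whose core differs in another place, so how a lighter halogen would compare with iodo here also remains open.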